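From 4-fluorophenyl to 3,4-dimethoxyphenyl

This account rests on a few compounds, and the source may have more. Where it says the series, first, only, none or still open, it means among the compounds named here.

In a functional assay on HeLa cells (Homo sapiens) for inhibition, read by MTT assay, with a stated time of 48 h (a lower number here means a stronger inhibitor of growth, a higher number a weaker inhibitor of growth), compound 1 `Cn1cc(C2CC(c3ccccc3)=NN2C(=O)c2ccncc2)c2ccccc21` gives 590 nM and compound 2 `Cn1cc(C2CC(c3ccc(F)cc3)=NN2C(=O)c2cccnc2)c2cc(Br)ccc21` gives 630 nM, which places compound 2 within the usual scatter of compound 1. Compound 3 `COc1ccc(C2=NN(C(=O)c3cccnc3)C(c3cn(C)c4ccc(Br)cc34)C2)cc1OC` carries 3,4-dimethoxyphenyl in place of 4-fluorophenyl on a carbon with a double bond to nitrogen. Going by the values given here, the two measured compounds differ in more than one place, so no measured step informs this change. In this assay, no shift beyond the scatter is expected in either direction, and the estimated change is a 1.1-fold higher number from compound 2 to compound 3 (0.05 log units; within the scatter). For compound 3 the expected value is 700 nM, with an estimated range of 250 nM to 2000 nM.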

Compound 3, concentration for 50% growth inhibition: 2090 nM
Compound 3: middle estimate off by 3.0-fold (0.48 log units), on the low side; measured number above the stated range.
By their numbers in this assay, from the lowest: compounds 1 and 2 (each within the scatter of the next); then compound 3.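

Going by these compounds alone, on a carbon with a double bond to nitrogen of the five-membered non-aromatic ring, 3,4-dimethoxyphenyl in place of 4-fluorophenyl gives a 3.3-fold higher number from compound 2 to compound 3 (0.52 log units; beyond the scatter) in this assay, a modest step and the first single-place comparison in this set. It shows that growth inhibition responds to the aryl group at this position, with weaker inhibition for the 3,4-dimethoxyphenyl group. No available evidence bears on why the number rises.

One step cannot separate the loss of fluorine from the gain of the two methoxy groups. Going by these compounds, whether a single methoxy group or an amine on that phenyl ring would shift the number in the same way remains open.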